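The source may report more compounds than this note shows. Statements on the series, on what has been measured and on what is new or still open speak of the compounds shown alone.

Among the compounds with values here, in an assay on isolated protein for inhibition of protein deacetylase HDAC6 (Homo sapiens), read by fluorescence, with a stated time of 15 min (a lower number here means a stronger inhibitor, a higher number a weaker inhibitor), compound 3 `COc1ccccc1-c1cc(/C=C/c2ccc(C(=O)NO)cc2)ccn1` gives 28 nM, the lowest of the three numbers so far. Compound 2 `O=C(NO)c1ccc(/C=C/c2ccnc(-c3ccccc3O)c2)cc1` gives 47 nM, and a 1.7-fold lower number from compound 2 to compound 3 (0.22 log units; within the scatter). Compound 1 `O=C(NO)c1ccc(/C=C/c2ccnc(-c3cc(F)ccc3O)c2)cc1` gives 130 nM; a 4.6-fold lower number from compound 1 to compound 3 (0.67 log units; beyond the scatter) and a 2.8-fold lower number from compound 1 to compound 2 (0.44 log units; beyond the scatter). Compound 4 `O=C(NO)c1ccc(/C=C/c2ccnc(-c3cccc(O)c3)c2)cc1` is not yet measured; it differs from compound 3 by 3-hydroxyphenyl in place of 2-methoxyphenyl on an aromatic carbon. Within the data shown here, the step bearing most directly on this is the methyl-for-hydrogen change on the oxygen between compound 2 and compound 3, which stayed within the scatter; no measured step tests a hydroxyl in the new position. For compound 4 the step of a 1.6-fold higher number from compound 3 to compound 4 (0.21 log units; within the scatter) in this assay is therefore expected to be small, if anything toward a somewhat higher number. Compound 4 is estimated at 45 nM, with a range of 15 nM to 130 nM.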

Compound 4, half-maximal inhibitory concentration: 19 nM
Beside the measured number, compound 4's estimate is 2.4-fold (0.37 log units) above it; low and high end bracket the measured number.
By their numbers in this assay, from the lowest: compounds 4, 3 and 2 (each within the scatter of the next, the first and the last beyond it); then compound 1.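

In this assay, 3-hydroxyphenyl in place of 2-hydroxyphenyl gives a 2.5-fold lower number from compound 2 to compound 4 (0.39 log units; beyond the scatter), the first sign that the placing of the hydroxyl on this phenyl ring counts at this position. Against 2-methoxyphenyl, the same group gives a 1.5-fold lower number from compound 3 to compound 4 (0.17 log units; within the scatter), so these two are not separated. The step of a 6.8-fold lower number from compound 1 to compound 4 (0.84 log units; beyond the scatter) changes both fluoro and hydroxyl placing, so it cannot be assigned to either.

No evidence on hand gives a cause for these steps. On these data alone, whether 3-methoxyphenyl or 3-aminophenyl would keep this level at the same position stays open.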